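Swapping 2-cyanophenyl for 1-acetylpiperidin-4-yl

The compounds below may be only part of what the source reports. "The series", "measured", "known", "first", "only" and "open" are said of these compounds alone.

Compound 1 `O=C(Nc1ccccc1Cl)N1CCC(c2nc(-c3ccc4ccccc4n3)no2)CC1`, compound 2 `O=C(NC1CCC(O)CC1)N1CCC(c2nc(-c3ccc4ccccc4n3)no2)CC1` and compound 3 `N#Cc1ccccc1NC(=O)N1CCC(c2nc(-c3ccc4ccccc4n3)no2)CC1` share one core and differ in the group on an amide-type nitrogen. In a functional assay on Shh Light II cells (Mus musculus) for inhibition, read by a luciferase reporter (a lower number here means a stronger inhibitor, a higher number a weaker inhibitor), compound 3 gives 190 nM, the lowest number of the three, against compound 1 at 510 nM and compound 2 at 2700 nM.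

Compound 4 `CC(=O)N1CCC(NC(=O)N2CCC(c3nc(-c4ccc5ccccc5n4)no3)CC2)CC1` carries 1-acetylpiperidin-4-yl in place of 2-cyanophenyl on that nitrogen: 1-acetylpiperidin-4-yl in place of 2-cyanophenyl on an amide-type nitrogen. For the measured compounds named here, the closest precedent is the 4-hydroxycyclohexyl group of compound 2, the only measured compound with a non-aromatic ring in this place. The large step of a 14-fold lower number from compound 2 to compound 3 (1.15 log units; beyond the scatter) bears most directly on the change, and the modest step of a 5.3-fold higher number from compound 1 to compound 2 (0.72 log units; beyond the scatter) points the same way. Neither compound 1 nor compound 3 goes against this pattern, but it rests on only these three compounds, and none of them carries the 1-acetylpiperidin-4-yl group.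

A large move to a weaker number in this assay is therefore expected, estimated as an 11-fold higher number from compound 3 to compound 4 (1.02 log units; beyond the scatter). The estimate for compound 4 is 2000 nM, with an expected range of 600 nM to 7000 nM.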

Compound 4, half-maximal inhibitory concentration: 500 nM
Compound 4: middle estimate off by 4.0-fold (0.60 log units), on the high side; measured number below the stated range.
By their numbers in this assay, from the lowest: compound 3; then compounds 4 and 1 (each within the scatter of the next); then compound 2.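

In this assay, a non-aromatic ring on the amide-type nitrogen proves far less costly than compound 2 alone suggested: leaving 2-cyanophenyl for 1-acetylpiperidin-4-yl gives only a 2.6-fold higher number from compound 3 to compound 4 (0.42 log units; beyond the scatter), while a 5.4-fold lower number from compound 2 to compound 4 (0.73 log units; beyond the scatter) shows that two non-aromatic rings at this place can differ clearly. With a 1.0-fold lower number from compound 1 to compound 4 (0.01 log units; within the scatter), the 1-acetylpiperidin-4-yl and 2-chlorophenyl groups cannot be told apart, so an aromatic ring is not needed to reach that level, although compound 3 keeps the lowest number of the four. Nothing in the data shown explains these steps.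

The compounds shown leave open whether the acetyl group contributes to this gain over the 4-hydroxycyclohexyl group or the ring nitrogen alone suffices. A free piperidin-4-yl amine or a 1-methylpiperidin-4-yl group would separate those two readings.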